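The compounds below may be only part of what the source reports. "The series", "measured", "known", "first", "only" and "open" are said of these compounds alone.

Values in an ADME assay on microsomes from liver (Rattus norvegicus) for metabolic stability, read by LC-MS, using NADPH, with stated times of 10 min and 60 min; a higher number here means that the compound lasts longer, a lower number that the compound disappears faster:
Compound 1 `CN1CCN(c2cc(CN(C)C3CCCc4cccnc43)nc(C3CC3)n2)CC1`: 0.017 h
Compound 2 `CN1CCN(c2cc(CN(C)C3CCCc4cccnc43)nc(N)n2)CC1`: 0.054 h
Compound 3 `Cc1nc(CN(C)C2CCCc3cccnc32)c(F)c(N2CCN(C)CC2)n1`: 0.0385 h

Compound 3 lies within the usual scatter of compound 2, and its number is higher than that of compound 1, beyond the scatter. Compound 4 `Cc1nc(CN(C)C2CCCc3cccnc32)c(C#N)c(N2CCN(C)CC2)n1` is compound 3 with one change, cyano in place of fluoro on an aromatic carbon, ortho to a 4-methylpiperazin-1-yl group (cyano in place of fluoro on an aromatic carbon). Among the measured compounds shown here, only one measured step offers any guide, and only loosely: a 3.2-fold higher number from compound 1 to compound 2 (0.50 log units; beyond the scatter), with amino in place of cyclopropyl elsewhere on the shared core. For the measured compounds named here, it shows that one swap can shift this number modestly, but no measured pair tests cyano against fluoro. In this assay, from the compounds shown here alone, no step beyond the scatter is therefore expected, and the direction stays open. The estimated step is a 1.0-fold higher number from compound 3 to compound 4 (0.02 log units; within the scatter). The expected half-life of compound 4 is 0.04 h, with an estimated range from 0.018 h to 0.09 h.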

Compound 4, half-life: 0.0252 h
Beside the measured number, compound 4's estimate is 1.6-fold (0.20 log units) above it; the range from low to high includes it.
By their numbers in this assay, from the lowest: compounds 1, 4, 3 and 2 (each within the scatter of the next, the first and the last beyond it).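

In this assay cyano in place of fluoro, ortho to a 4-methylpiperazin-1-yl group and para to a methyl group, gives a 1.5-fold lower number from compound 3 to compound 4 (0.18 log units; within the scatter) and so stays within the usual scatter. This is the only swap shown at this position on the shared core, and by this read-out cyano and fluoro cannot be told apart there.

From the compounds shown here alone, whether an amine or a methoxy group at the same position would carry the half-life beyond the scatter stays open. Nothing shown gives a reason why cyano and fluoro read alike here.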